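The source may hold more compounds than are shown below. What is called first, only, known or untested is meant among the compounds shown, and "the series" means these compounds.

In a functional assay on MCF7 cells (Homo sapiens) for inhibition, read by trypan blue exclusion, with a stated time of 3 days (a higher number here means a weaker inhibitor, a lower number a stronger inhibitor), three compounds have numbers so far:

compound 1 `COc1cc(C(=O)c2cn(-c3ccccc3)cc2-c2ccc(N)cc2)cc(OC)c1OC` gives 9 nM
compound 2 `COc1cc(C(=O)c2cn(-c3ccccc3F)cc2-c2ccccc2)cc(OC)c1OC` gives 85 nM
compound 3 `COc1cc(C(=O)c2cn(-c3cccc(C)c3)cc2-c2ccccc2)cc(OC)c1OC` gives 120 nM

On paper compound 3 carries the highest of these three numbers, but the gap to its nearest neighbour is small: a 1.4-fold higher number from compound 2 to compound 3 (0.15 log units; within the scatter). Those two therefore stand level, while the number of compound 1 is clearly lower than that of compound 3.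

The next compound, compound 4 `COc1cc(C(=O)c2cn(-c3cccc(F)c3)cc2-c2ccccc2)cc(OC)c1OC`, differs from compound 3 in one group: fluoro in place of methyl on an aromatic carbon. This is fluoro in place of methyl on an aromatic carbon, turning 3-methylphenyl into 3-fluorophenyl.

Among the compounds with values here, no measured step makes exactly this swap. The closest evidence is the pair already mentioned, where 2-fluorophenyl and 3-methylphenyl sit in the same place on the shared core and the step stays within the scatter. Compound 1 differs from compound 3 in more than one place, so it offers no direct guide. Within the data shown here, with only this one small step to go on, no shift beyond the scatter is expected.

The expected step is a 1.2-fold lower number from compound 3 to compound 4 (0.08 log units; within the scatter). For compound 4 the estimate is 100 nM, with an expected range from 45 nM to 220 nM.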

Compound 4, half-maximal inhibitory concentration: 350 nM
Compound 4: the middle estimate sits 3.5-fold (0.54 log units) below what was measured; measured number outside the range, above it.
By their numbers in this assay, from the lowest: compound 1; then compounds 2 and 3 (each within the scatter of the next); then compound 4.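

In this assay, within the data shown here, the group on the aromatic nitrogen proves sensitive to very small changes, something the earlier compounds did not reveal, since 2-fluorophenyl and 3-methylphenyl had stood level. Fluoro in place of methyl exchanges one heavy atom for one, with no change in the counted hydrogen-bond donors, acceptors or charge, yet it gives a 2.9-fold higher number from compound 3 to compound 4 (0.46 log units; beyond the scatter), and shifting the fluoro from 2-fluorophenyl to 3-fluorophenyl gives a 4.1-fold higher number from compound 2 to compound 4 (0.61 log units; beyond the scatter), so in these compounds a fluoro does not count the same wherever it sits on this ring, and both steps point the same way, towards a weaker inhibitor. Nothing available here accounts for either step, so the reason for this sensitivity remains unknown.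

The compounds shown leave open how other small groups, such as chloro or nitrile, would behave in the place held by methyl and fluoro, and so whether the methyl or the fluoro is the unusual one. Going by these compounds, it also stays open whether the amine carried by compound 1 would lower the number if it were added to compound 4.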